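The source may report more compounds than this note shows. Statements on the series, on what has been measured and on what is new or still open speak of the compounds shown alone.

In a physicochemical assay, with a stated time of 6 min (a higher number here means a weaker inhibitor, a lower number a stronger inhibitor), compound 1 `O=C(Nc1ccc(Br)cc1)Nc1nc(-c2cc3ccccc3o2)cs1` gives > 200000 nM, which is a limit of the assay and not a number. Compound 2 `O=C(Nc1ccc([N+](=O)[O-])cc1)Nc1nc(-c2cc3cc(Br)ccc3o2)cs1` gives > 200000 nM, also a limit. Compound 1 therefore stands at the limit of > 200000 nM in this assay, at which 2 of the 2 values shown sit, and no measured number yet exists to compare it with. Compound 3 `O=C(Nc1cccc(Cl)c1)Nc1nc(-c2cc3ccccc3o2)cs1` has 3-chlorophenyl in place of 4-bromophenyl on an amide-type nitrogen. For the measured compounds named here, no measured step shows what such a swap does, so no change beyond the scatter is expected in this assay, and the estimated step is a number no higher from compound 1 to compound 3 (the limit leaves the size open). Compound 3 is estimated at 200000 nM, with an expected range of 50000 nM to 400000 nM.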

Compound 3, half-maximal inhibitory concentration: 14100 nM
Compound 3: the middle estimate sits 14-fold (1.15 log units) above what was measured, and the stated range ends above it.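

The aryl group on this amide-type nitrogen clearly matters in this assay: 3-chlorophenyl in place of 4-bromophenyl gives an at least 14-fold lower number from compound 1 to compound 3 (1.15 log units; beyond the scatter). Compound 3 alone carries a measured number, which gives later changes something to be compared with, since the other values shown are limits: the limit of > 200000 nM in this assay, at which 2 of the 3 values shown sit.

This single swap exchanges bromine for chlorine and also moves the halogen, and the two changes cannot be told apart here. From the compounds shown here alone, what an amine or a carboxylic acid would do on that ring in place of the halogen also stays open.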